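Swapping trifluoromethyl for carbamoyl on a shared core

This account rests on a few compounds, and the source may have more. Where it says the series, first, only, none or still open, it means among the compounds named here.

Compound 1 `CCc1ccc(NC(=O)Nc2cc(C)nc3ccccc23)cc1` gives > 25000 nM
Compound 2 `Cc1cc(NC(=O)Nc2ccc(C(F)(F)F)cc2)c2ccccc2n1` gives 23000 nM

Among the measured compounds shown here, in an ADME assay on Raji cells (Homo sapiens) for cytotoxicity, with a stated time of 72 h (on this read-out lower numbers stand for an effect already at smaller amounts and higher numbers for an effect only at larger amounts of compound), compound 2 gives 23000 nM as the only actual number so far. For compound 1 the assay reports only a limit, > 25000 nM in this case. For the measured compounds named here, the one measured step is an at least 1.0-fold lower number from compound 1 to compound 2 (0.03 log units; that floor lies within the scatter) with trifluoromethyl in place of ethyl on an aromatic carbon. Compound 3 `Cc1cc(NC(=O)Nc2ccc(C(N)=O)cc2)c2ccccc2n1` differs from compound 2 by carbamoyl in place of trifluoromethyl on an aromatic carbon with carbamoyl in place of trifluoromethyl on an aromatic carbon. Going by an at least 1.0-fold lower number from compound 1 to compound 2 (0.03 log units; that floor lies within the scatter) as the only guide, no step beyond the scatter is expected in this assay here. Compound 3 is estimated at 25000 nM with an expected range of 10000 nM to 50000 nM around it. This estimate means a 1.1-fold higher number from compound 2 to compound 3 (0.04 log units; within the scatter) as the expected step.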

Compound 3, half-maximal effective concentration: > 25000 nM
Compound 3 ended at the assay's limit (the forecaster's own chance of this, stated with the estimate: 65%); the middle value lies on the limit itself.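

Putting carbamoyl, with its hydrogen-bond donor and acceptor, in place of trifluoromethyl gives an at least 1.0-fold higher number from compound 2 to compound 3 (0.03 log units; that floor lies within the scatter), so in this assay this position shows no clear response to the swap. The step between compound 1 and compound 3 cannot be read, as both values are limits. Little more can be said about this position because the values crowd against the top of the range: the limit of > 25000 nM in this assay, at which 2 of the 3 values shown sit.

On these data alone, whether an amine or a carboxylic acid at this place would give a clearly lower number stays open.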